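A few compounds are considered here, and "the series" means these few. Any claim that something is new, unique, unknown or untested is made for them only; others in the source may bear on it.

Measured so far in an assay on isolated protein for inhibition of histone acetyltransferase p300 (Homo sapiens), with a stated time of 60 min; on this read-out higher numbers stand for weaker inhibition and lower numbers for stronger inhibition:
- compound 1 `O=C(Nc1ccc2[nH]ccc2n1)[C@H]1CCCN1C(=O)C1(c2cccc(Cl)c2)CCCC1`: 0.159 nM
- compound 2 `COc1ccc(C2(C(=O)N3CCC[C@@H]3C(=O)Nc3ccc4[nH]ncc4n3)CCC2)cc1`: 0.251 nM

Both numbers are sub-nanomolar. Compound 1 stands at one end of the pair, but its gap to compound 2 lies within the usual scatter, so the two are not distinguished by this assay and neither can be called the more potent. Among the measured compounds shown here, no single-point step between measured compounds is available; the two differ in more than one place.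

Compound 3 `O=C1Cc2cc(NC(=O)[C@H]3CCCN3C(=O)C3(c4cccc(Cl)c4)CCCC3)ccc2N1` is not yet measured. It differs from compound 1 by a group of 10 heavy atoms (8 carbon, 1 nitrogen, 1 oxygen; one five-membered non-aromatic ring with 1 hetero atom, one six-membered aromatic ring of carbon only) in place of a group of 9 heavy atoms (7 carbon, 2 nitrogen; one five-membered aromatic ring with 1 hetero atom, one six-membered aromatic ring with 1 hetero atom), on an amide-type nitrogen. For the measured compounds named here, with no comparable step among the measured compounds, the size of the change can only be judged from the magnitude of the substitution itself: a whole bicyclic group exchanged at the amide nitrogen. The expectation is a weakening beyond the scatter, of the size a 5.0-fold higher number from compound 1 to compound 3 (0.70 log units; beyond the scatter). Compound 3 is therefore estimated at 0.8 nM, with a plausible range from 0.15 nM to 5 nM.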

Compound 3, half-maximal inhibitory concentration: 0.794 nM
Compound 3: the middle estimate sits 1.0-fold (0.00 log units) above what was measured; measured number inside the range.
By their numbers in this assay, from the lowest: compounds 1 and 2 (each within the scatter of the next); then compound 3.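

In this assay, among the compounds shown here, the exchange on the amide-type nitrogen gives a 5.0-fold higher number from compound 1 to compound 3 (0.70 log units; beyond the scatter) and thus the first readable step: this position responds to the group it carries, though only modestly for a change of a whole bicyclic group, and compound 3 still gives a sub-nanomolar 0.794 nM. Both groups count 1 hydrogen-bond donor and 1 hydrogen-bond acceptor, so the step arises with these counts unchanged. No measurement in hand accounts for the step.

The step changes both rings at once, so the share of the ring nitrogen and that of the carbonyl in the five-membered non-aromatic ring stay unseparated. On these data alone, whether a single unfused ring, such as a plain pyridine on the amide-type nitrogen, would hold the number also remains open.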